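Chain swap in a series held at limits

The source may hold more compounds than are shown below. What is called first, only, known or untested is meant among the compounds shown, and "the series" means these compounds.

Compound 3 (`CC/C=C\C/C=C\C/C=C\CCCCCCCc1cc(=O)c2c(O)c(C)c(OCOC)c(C)c2o1`) gives > 84100 nM in a functional assay on MCF7 cells (Homo sapiens) for antiproliferative activity, read by MTT assay (a higher number here means a weaker inhibitor, a lower number a stronger inhibitor), and this is a limit, not a number. Compound 1 (`CCCCC/C=C\C/C=C\CCCCCCCc1cc(=O)c2c(O)c(C)c(OCOC)c(C)c2o1`) gives > 84100 nM and this too is a limit. Compound 2 (`CCCC/C=C\CCCCCCCCCc1cc(=O)c2c(O)c(C)c(OCOC)cc2o1`) gives > 67200 nM as a limit also. Within the data shown here, the only measured step is a step that the two limits leave unreadable from compound 1 to compound 3 and it offers no size to carry forward.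

Compound 4 (`CCCC/C=C\CCCCCCCCCc1cc(=O)c2c(O)c(C)c(OCOC)c(C)c2o1`) keeps the core of compound 3 and brings oct-3-en-1-yl: a group of 8 heavy atoms (8 carbon; no ring) in place of a group of 10 heavy atoms (10 carbon; no ring), on a saturated chain carbon, seven bonds along the chain from an aromatic carbon.

Compound 3 supports expecting no readable step in this assay because compound 3 has > 84100 nM as its limit. The expected step is a number no higher from compound 3 to compound 4 (the limit leaves the size open) and nothing beyond the scatter. Compound 4 is estimated at 84000 nM with an expected range of 35000 nM to 170000 nM and will probably be reported as a limit.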

Compound 4, half-maximal inhibitory concentration: > 67200 nM
Compound 4 was reported as a limit (the forecaster's own chance of this, stated with the estimate: 85%); the middle value does not contradict the limit.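

Among these compounds, compound 4, like compound 1, compound 2 and compound 3, stands only as a limit, so no step among them can be read. The compounds shown leave open whether chain or methyl changes matter in this assay.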